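This account rests on a few compounds, and the source may have more. Where it says the series, first, only, none or still open, it means among the compounds named here.

Of the compounds shown here, three sharing one core have been measured in a functional assay on HT-1080 cells (Homo sapiens) for cytotoxicity, read by MTT assay, with a stated time of 72 h; a lower number here means a stronger inhibitor, a higher number a weaker inhibitor. Compound 1 `COc1ccc(Cn2nc(-c3ccccc3)c3cc(C(=N)Nc4ccc(N5CCN(C)CC5)cc4)nc(Nc4cc(OC)c(OC)c(OC)c4)c32)cc1` gives 1200 nM. Compound 2 `CN1CCN(c2ccc(NC(=N)c3cc4c(-c5ccccc5)n[nH]c4c(NC4CCCCC4)n3)cc2)CC1` gives 650 nM. Compound 3 `COc1ccc(Cn2nc(-c3ccccc3)c3cc(C(=N)Nc4ccccc4)nc(NC4CCCCC4)c32)cc1` gives 3400 nM, the highest of the three numbers and beyond the scatter from both of the others. Compound 4 `COc1ccc(Cn2nc(-c3ccccc3)c3cc(C(=N)Nc4ccc(N5CCN(C)CC5)cc4)nc(NC4CCCCC4)c32)cc1` has not yet been measured. Compound 4 differs from compound 3 by 4-methylpiperazin-1-yl in place of hydrogen on an aromatic carbon. Among the measured compounds shown here, no directly comparable step has been measured, yet the same group is carried by compound 1 with 1200 nM and by compound 2 with 650 nM, both lower than compound 3. A downward step beyond the scatter is therefore expected: a 3.4-fold lower number from compound 3 to compound 4 (0.53 log units; beyond the scatter). For compound 4 the estimate is 1000 nM, expected between 400 nM and 2500 nM.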

Compound 4, half-maximal inhibitory concentration: 640 nM
Compound 4: the middle estimate sits 1.6-fold (0.19 log units) above what was measured; the measured number falls inside the stated range.
By their numbers in this assay, from the lowest: compounds 4, 2 and 1 (each within the scatter of the next); then compound 3.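

In this assay, among the compounds shown here, adding 4-methylpiperazin-1-yl on the aromatic carbon (a 5.3-fold lower number from compound 3 to compound 4 (0.73 log units; beyond the scatter)) gives the first direct reading of this group with the rest of the molecule unchanged. With this group in place, the two other single changes stay within the scatter: 4-methoxybenzyl in place of hydrogen on the aromatic nitrogen (a 1.0-fold lower number from compound 2 to compound 4 (0.01 log units; within the scatter)) and cyclohexyl in place of 3,4,5-trimethoxyphenyl (a 1.9-fold lower number from compound 1 to compound 4 (0.27 log units; within the scatter)). No measured evidence bears on this result. As far as these compounds go, whether morpholine or a dimethylamino group on this carbon would give a similar step remains open.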